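A few compounds are considered here, and "the series" means these few. Any claim that something is new, unique, unknown or untested is made for them only; others in the source may bear on it.

Measured so far in a functional assay on MCF7 cells (Homo sapiens) for cytotoxicity, read by MTT assay (a higher number here means a weaker inhibitor, a lower number a stronger inhibitor), each entry a limit and not a number:
- compound 1 `CC1(C)C=Cc2c([C@H]3CCc4ccc(O)cc4O3)ccc(O)c2O1` gives > 100000 nM (limit)
- compound 2 `CC1(C)C=Cc2c(C3CCc4ccc(O)cc4O3)ccc(O)c2O1` gives > 100000 nM (limit)
- compound 3 `CC1(C)CCc2c([C@H]3CCc4ccc(O)cc4O3)ccc(O)c2O1` gives > 100000 nM (limit)

Compound 2 stands only at a limit, namely (the limit of > 100000 nM in this assay, at which 3 of the 3 values shown sit), so no number places it among the others.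

The move to compound 4 `CC1(C)C=Cc2c([C@@H]3CCc4ccc(O)cc4O3)ccc(O)c2O1` is the two compounds have the same atoms and bonds; at least one stereo element is drawn with a configuration in one of them and without one in the other: 1 of 1 stereo elements differ; a stereocentre at a saturated ring carbon is drawn without a configuration in compound 2 and S in compound 4 and the atoms and bonds stay the same: a stereocentre at a saturated ring carbon is drawn without a configuration in compound 2 and S in compound 4.

Among the compounds with values here, the one measured step of this kind is a step that the two limits leave unreadable from compound 1 to compound 2 and it concerns (the fact that one of compounds 1 and 2 is drawn with a defined configuration and the other without, at the place where they differ), so it offers no size to carry over. No step beyond the scatter is expected and no direction can be read, which leaves the expected change as a step that the limit leaves unreadable from compound 2 to compound 4 in this assay for now.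

Compound 4 is estimated at 150000 nM within an expected range of 70000 nM to 300000 nM and will most likely be reported as a limit again.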

Compound 4, half-maximal inhibitory concentration: > 100000 nM
Compound 4 gave a limit, no number; the forecaster's own chance of this, stated with the estimate: 90%; the middle value lies beyond the limit too.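

In this assay compound 4 gives > 100000 nM, a limit. Within the data shown here, no new step can therefore be read among compound 1, compound 2 and compound 4. Whether the configuration at the saturated ring carbon affects cytotoxicity at all stays open, because every value sits at one limit: the limit of > 100000 nM in this assay, at which 4 of the 4 values shown sit.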